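Swapping Methoxy for Piperidinyl on the Aromatic Ring

A few compounds are considered here, and "the series" means these few. Any claim that something is new, unique, unknown or untested is made for them only; others in the source may bear on it.

Of the compounds shown here, two sharing one core have been measured so far. Compound 1, `CCN1CC[C@@]2(OC)OC(N)=C(C#N)[C@@H](c3ccc(Br)cc3)[C@@H]2C1`, gives 13200 nM in a functional assay on trachea (Cavia porcellus); a lower number here means a stronger inhibitor, a higher number a weaker inhibitor. Compound 2, `CCN1CC[C@@]2(OC)OC(N)=C(C#N)[C@@H](c3ccc(OC)cc3)[C@@H]2C1`, differs only in the group on the aromatic ring and gives 25500 nM in this assay. The step of a 1.9-fold higher number from compound 1 to compound 2 (0.29 log units; within the scatter) is small, so on the numbers shown compound 2 stands essentially level with compound 1, the two being within the usual scatter of each other.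

Compound 3, `CCN1CC[C@@]2(OC)OC(N)=C(C#N)[C@@H](c3ccc(N4CCCCC4)cc3)[C@@H]2C1`, is the next step from compound 2. The change is piperidin-1-yl in place of methoxy on an aromatic carbon. Among the measured compounds shown here, only one measured step bears on this position, the one from compound 1 to compound 2, and that step was a 1.9-fold higher number from compound 1 to compound 2 (0.29 log units; within the scatter), within the scatter. For the measured compounds named here, there is nothing in the measured pair that points to a move in either direction beyond the scatter, so no step of size is expected in this assay.

Compound 3 is therefore estimated at 22000 nM in this assay, with a range from 6000 nM to 80000 nM. This estimate means an expected step of a 1.2-fold lower number from compound 2 to compound 3 (0.06 log units; within the scatter).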

Compound 3, half-maximal inhibitory concentration: 13800 nM
For compound 3 the middle estimate is 1.6-fold (0.20 log units) above the measured one, within the range that was stated.
By their numbers in this assay, from the lowest: compounds 1, 3 and 2 (each within the scatter of the next).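

In this assay piperidin-1-yl in place of methoxy gives a 1.8-fold lower number from compound 2 to compound 3 (0.27 log units; within the scatter) and piperidin-1-yl in place of bromo gives a 1.0-fold higher number from compound 1 to compound 3 (0.02 log units; within the scatter) so the three groups cannot be told apart at this position. The earlier pair compared only bromo with methoxy, whereas this change replaces methoxy, with its 2 heavy atoms and no ring, by a group of 6 heavy atoms that carries a six-membered non-aromatic ring, and even so the step stays within the scatter. No evidence is available to explain why these compounds read so alike.

Among the compounds shown here, what the three compounds leave open is whether any group at this position can move the number beyond the scatter, since every step so far lies within it. A carboxylic acid, a primary amine or a longer chain ending in a hydroxyl group on the same aromatic carbon would test this, and each would show whether the flat reading holds for groups unlike bromo, methoxy and piperidin-1-yl.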